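A few compounds are considered here, and "the series" means these few. Any claim that something is new, unique, unknown or untested is made for them only; others in the source may bear on it.

Three compounds of the series have been run in an assay on isolated protein for inhibition of matrix metalloproteinase-9 (Homo sapiens); on this read-out higher numbers stand for weaker inhibition and lower numbers for stronger inhibition. Compound 1 `O=C(OCc1ccccc1Br)c1cccc(S)n1` returns only the limit of this assay, > 150000 nM, a limit and not a number (the limit of > 150000 nM in this assay, at which 1 of the 3 values shown sits). Compound 2 `O=C(OCc1cccc(-c2ccccc2)c1)c1cccc(S)n1` gives 50000 nM in this assay. Compound 3 `O=C(OCc1ccccc1Cl)c1cccc(=O)[nH]1`, built on a different core, gives 81000 nM; compound 2 and compound 3 sit within the usual scatter of each other and cannot be told apart on these numbers. Compound 2 thus holds one of two plain numbers, both at the weak end of what this assay reports.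

Compound 4 `COc1cccc(COC(=O)c2cccc(S)n2)c1` keeps the core of compound 2 and differs at one place: methoxy in place of phenyl on an aromatic carbon. The phenyl leaves and a methoxy enters on the same aromatic carbon, meta to a large group. Going by the values given here, no step between measured compounds covers such a change. For compound 4 the expectation in this assay is a modest shift toward a weaker value, near the edge of the scatter, a 1.7-fold higher number from compound 2 to compound 4 (0.23 log units; within the scatter). Compound 4 is estimated at 85000 nM, with a range from 30000 nM to 250000 nM, and a real chance that only a limit is returned.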

Compound 4, half-maximal inhibitory concentration: 93000 nM
For compound 4 the middle estimate is 1.1-fold (0.04 log units) below the measured one, within the range that was stated.
By their numbers in this assay, from the lowest: compounds 2, 3 and 4 (each within the scatter of the next). At a limit, above all of these: compound 1.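

In this assay, methoxy in place of phenyl on this aromatic carbon gives a 1.9-fold higher number from compound 2 to compound 4 (0.27 log units; within the scatter), so the two compounds cannot be told apart. This position therefore accepts the loss of the six-membered aromatic ring, with only 2 heavy atoms entering in place of 6, and compound 4 still returns a plain number on the same core as compound 2. Compound 1 remains the only compound at a limit, which is not a number: the limit of > 150000 nM in this assay, at which 1 of the 4 values shown sits.

On these data alone, whether any group on this aromatic carbon can move the value beyond the scatter stays open, for example an amine, a carboxylic acid or a longer alkoxy chain. Also open, as far as these compounds go, is whether a change at this position can lift the series away from the weak end of this assay.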